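This account rests on a few compounds, and the source may have more. Where it says the series, first, only, none or still open, it means among the compounds named here.

Measured compounds in an ADME assay on microsomes from liver (Homo sapiens) for metabolic stability, read by LC-MS, tested at 1 uM; a higher number here means faster removal of the compound, a lower number slower removal:
- compound 1, `NCCOCCOc1ccc([C@H]2CC[C@]3(CC2)OOC2(O3)C3CC4CC(C3)CC2C4)cc1`: < 7 mL.min-1.g-1
- compound 2, `NC(=O)C1CCN(Cc2ccc([C@H]3CC[C@]4(CC3)OOC3(O4)C4CC5CC(C4)CC3C5)cc2)CC1`: 10 mL.min-1.g-1
- compound 3, `CC(C)(O)CN1CCC(Oc2ccc([C@H]3CC[C@]4(CC3)OOC3(O4)C4CC5CC(C4)CC3C5)cc2)CC1`: 18 mL.min-1.g-1

Compound 1 gives only a limit of the assay, (the limit of < 7 mL.min-1.g-1 in this assay, at which 1 of the 3 values shown sits); its true value is not known, so it stands at the low end of what has been seen here. Compound 2 gives 10 mL.min-1.g-1 and compound 3 gives 18 mL.min-1.g-1 in this assay.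

Compound 4 is `CS(=O)(=O)N1CCN(CCCOc2ccc([C@H]3CC[C@]4(CC3)OOC3(O4)C4CC5CC(C4)CC3C5)cc2)CC1`. It differs from compound 1 as follows: (4-(methylsulfonyl)piperazin-1-yl)methyl in place of 2-aminoethoxy on a saturated chain carbon, two bonds along the chain from an oxygen on an aromatic ring.

Two measured steps start from compound 1 and both swap the 2-(2-aminoethoxy)ethoxy side chain for a saturated nitrogen ring: an at least 1.4-fold higher number from compound 1 to compound 2 (0.15 log units; that floor lies within the scatter) and an at least 2.5-fold higher number from compound 1 to compound 3 (0.41 log units; beyond the scatter). Both read higher, the second beyond the scatter, the first only as a floor within it. Compound 4 likewise carries a saturated nitrogen ring in place of the free primary amine of compound 1, so a step upward is expected, of the same order as those two, though the limit on compound 1 leaves its size uncertain.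

For compound 4 the expected step is an at least 1.7-fold higher number from compound 1 to compound 4 (0.23 log units; that floor lies within the scatter). Compound 4 is therefore estimated at 12 mL.min-1.g-1, within 5 mL.min-1.g-1 to 28 mL.min-1.g-1.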

Compound 4, intrinsic clearance in microsomes: 68 mL.min-1.g-1
The estimate for compound 4 lay 5.7-fold (0.75 log units) below the measured number; measured number outside the range, above it.
By their numbers in this assay, from the lowest: compounds 2 and 3 (each within the scatter of the next); then compound 4. At a limit, below all of these: compound 1.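

In this assay, the change on the saturated chain carbon, two bonds along the chain from an oxygen on an aromatic ring, gives an at least 9.7-fold higher number from compound 1 to compound 4 (0.98 log units; beyond the scatter). The oxygen on the aromatic ring stays in place here, so a change at this outer position alone is enough to move the number beyond the scatter, whereas the steps to compound 2 and compound 3 replaced the side chain further in. The step is only a floor and its true size is unknown, since the number for compound 1 is a limit: the limit of < 7 mL.min-1.g-1 in this assay, at which 1 of the 4 values shown sits.

The entering (4-(methylsulfonyl)piperazin-1-yl)methyl differs from 2-aminoethoxy in its ring, its methylsulfonyl and its hydrogen-bond donor count, and the compounds shown do not separate these differences. An acetyl in place of the methylsulfonyl on the piperazine, a morpholine on the same chain, or a shorter chain carrying the same methylsulfonyl piperazine would show which part goes with the higher number in this assay.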